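The compounds below may be only part of what the source reports. "The series", "measured", "known", "first", "only" and "open" are said of these compounds alone.

In an assay on BTI-TN-5B1-4 cells for inhibition of Amine oxidase [flavin-containing] B (Homo sapiens), read by fluorescence and Amplex Red, using microsomes, with a stated time of 30 min (a lower number here means a stronger inhibitor, a higher number a weaker inhibitor), compound 3 `C#CCOc1ccc(-c2cc(-c3ccc(OCC#C)c(OCC)c3)nc(C)n2)cc1` gives 11000 nM, the lowest of the three numbers shown, though compound 1 `C#CCOc1ccc(-c2cc(-c3ccc(OCC#C)c(OC)c3)nc(-c3ccccc3)n2)cc1` at 15700 nM and compound 2 `C#CCOc1ccc(-c2cc(-c3ccc(OCC#C)c(OC)c3)nc(N)n2)cc1` at 20000 nM both lie within the scatter of it. For the measured compounds named here, the one single-place step measured, a 1.3-fold higher number from compound 1 to compound 2 (0.11 log units; within the scatter), is itself within the scatter. Compound 4 `C#CCOc1ccc(-c2cc(-c3ccc(OCC#C)c(OC)c3)nc(C)n2)cc1` carries hydrogen in place of methyl on a saturated chain carbon bound to an oxygen on an aromatic ring, that is, ethoxy to methoxy. Going by the values given here, no measured step covers this change on its own: compound 1 and compound 2 both carry the methoxy, but each also differs from compound 3 in another place. No step beyond the scatter is therefore expected. Compound 4 is estimated at 12000 nM in this assay, within 5000 nM to 30000 nM, which means an expected step of a 1.1-fold higher number from compound 3 to compound 4 (0.04 log units; within the scatter).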

Compound 4, half-maximal inhibitory concentration: 21100 nM
For compound 4 the middle estimate is 1.8-fold (0.25 log units) below the measured one; low and high end bracket the measured number.
By their numbers in this assay, from the lowest: compounds 3, 1, 2 and 4 (each within the scatter of the next).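

In this assay, for the compounds shown here, ethoxy to methoxy, on a saturated chain carbon bound to an oxygen on an aromatic ring, gives a 1.9-fold higher number from compound 3 to compound 4 (0.28 log units; within the scatter) as the first reading of this change on its own. On the aromatic carbon that varies elsewhere, a 1.1-fold higher number from compound 2 to compound 4 (0.02 log units; within the scatter) and a 1.3-fold higher number from compound 1 to compound 4 (0.13 log units; within the scatter) join the earlier amino and phenyl step, so methyl, amino and phenyl are not separated there. Nothing available explains any of these steps. Going by these compounds, whether a propoxy group or longer chain at this oxygen would leave the scatter remains open. Also open, on these data alone, is whether ethoxy and methoxy read alike with amino or phenyl in place of methyl, or how a carboxylic acid on that aromatic carbon would read.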